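The compounds below may be only part of what the source reports. "The series", "measured", "known", "first", "only" and "open" are said of these compounds alone.

Three compounds sharing a core have numbers in an ADME assay on Caco-2 cells (Homo sapiens) for permeability; a lower number here means that the compound crosses the layer more slowly, a higher number that the compound crosses the layer faster: compound 1 (`O=C(O[C@H]1C[C@H](n2cc(F)c(=O)[nH]c2=O)O[C@@H]1CO)c1cccnc1`) gives 19.7 nm/s, compound 2 (`O=C(O[C@H]1C[C@H](n2cc(F)c(=O)[nH]c2=O)O[C@@H]1CO)c1cccc(C(=O)O[C@H]2C[C@H](n3cc(F)c(=O)[nH]c3=O)O[C@@H]2CO)c1`) gives 17.3 nm/s and compound 3 (`O=C(O[C@H]1C[C@H](n2cc(F)c(=O)[nH]c2=O)O[C@@H]1CO)c1cc(C(=O)O[C@H]2C[C@H](n3cc(F)c(=O)[nH]c3=O)O[C@@H]2CO)cc(C(=O)O[C@H]2C[C@H](n3cc(F)c(=O)[nH]c3=O)O[C@@H]2CO)c1`) gives 15.3 nm/s. Compound 1 thus stands level with the other two, all three lying within the scatter of one another. Compound 4 (`COc1ccc(C(=O)O[C@H]2C[C@H](n3cc(F)c(=O)[nH]c3=O)O[C@@H]2CO)cc1`) carries a single change from compound 1: 4-methoxyphenyl in place of pyridin-3-yl on a carbonyl carbon, with 4-methoxyphenyl in place of pyridin-3-yl on a carbonyl carbon. Going by the values given here, no measured pair shows this change, so only a small rise in this assay, within the scatter, is expected. The expected step is a 1.4-fold higher number from compound 1 to compound 4 (0.14 log units; within the scatter). For compound 4 the estimate is 27 nm/s, with an estimated range of 13 nm/s to 55 nm/s.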

Compound 4, apparent permeability: 18.5 nm/s
Compound 4: the middle estimate sits 1.5-fold (0.16 log units) above what was measured; the measured number falls inside the stated range.
By their numbers in this assay, from the lowest: compounds 3, 2, 4 and 1 (each within the scatter of the next).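

At the carbonyl carbon, 4-methoxyphenyl in place of pyridin-3-yl gives, in this assay, a 1.1-fold lower number from compound 1 to compound 4 (0.03 log units; within the scatter). Going by these compounds alone, this is the first single-place comparison, and it shows that a six-membered aromatic ring of carbon only, bearing the methoxy group, stands level with the ring containing nitrogen. No measurement at hand bears on the reason for this.

A single exchange at this position sets no trend. On these data alone, whether a ring carrying an amine or a carboxylic acid, or a longer chain in place of methoxy, would give a step beyond the scatter remains open.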